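The source may report more compounds than this note shows. Statements on the series, on what has been measured and on what is new or still open speak of the compounds shown alone.

Of the compounds shown here, three sharing one core have been read in a functional assay on KB cells (Homo sapiens) for cytotoxicity, read by MTT assay, with a stated time of 72 h; on this read-out lower numbers stand for an effect already at smaller amounts and higher numbers for an effect only at larger amounts of compound. Compound 1 `CCc1cccc2c(O)c(-c3occ(C)c3C(=O)O)ccc12` gives 9.1 ug/mL. Compound 2 `CCOc1c(-c2occ(C)c2C(=O)O)ccc2c(CC)cccc12` reaches only a limit of the assay, > 10 ug/mL. Compound 3 `CCOC(=O)c1c(C)coc1-c1ccc2c(CC)cccc2c1OC` gives 2.2 ug/mL, the lower of the two actual numbers, and this value lies under that of compound 1.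

Compound 4 `CCc1cccc2c(OC)c(-c3occ(C)c3C(=S)OC)ccc12` departs from compound 3 at one place: a group of 4 heavy atoms (2 carbon, 1 oxygen, 1 sulfur; no ring) in place of a group of 5 heavy atoms (3 carbon, 2 oxygen; no ring), on an aromatic carbon. The ethoxycarbonyl leaves from an aromatic carbon of a five-membered aromatic ring with 1 oxygen.

Among the compounds with values here, the only measured step is an at least 1.0-fold higher number from compound 1 to compound 2 (0.04 log units; that floor lies within the scatter), which comes with ethyl in place of hydrogen on an oxygen on an aromatic ring. On these data alone, its size stays open, as it ends at the limit of > 10 ug/mL in this assay, at which 1 of the 3 values shown sits. That step lies elsewhere on the molecule and does not touch the group that changes here. Compound 1 and compound 3 differ in more than one place, so their gap gives no clean measure of this change either.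

The expectation therefore starts from compound 3 at 2.2 ug/mL, with no direction that the data can support in this assay. The expected size of the move, a 1.1-fold higher number from compound 3 to compound 4 (0.06 log units; within the scatter), stays within the scatter. For compound 4 the estimated value is 2.5 ug/mL, with an expected range from 0.8 ug/mL to 8 ug/mL.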

Compound 4, concentration for half-maximal effect: 4.3 ug/mL
Estimate against measurement, compound 4: 1.7-fold (0.24 log units) below; low and high end bracket the measured number.
By their numbers in this assay, from the lowest: compounds 3 and 4 (each within the scatter of the next); then compound 1. At a limit, above all of these: compound 2.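

In this assay this position now has its first measured step, a 2.0-fold higher number from compound 3 to compound 4 (0.29 log units; within the scatter), so the two compounds cannot be told apart on this read-out. On an aromatic carbon of the five-membered aromatic ring with 1 oxygen, the ethoxycarbonyl can therefore give way to the group of 4 heavy atoms that carries sulfur, with no change beyond the scatter, and the counts of hydrogen-bond donors and acceptors stay the same across the exchange. Nothing measured among these compounds offers a cause for this step or bears on it directly.

The exchange alters two things at once, the length of the chain on the oxygen and the sulfur in the group, so a methyl ester on the same carbon would be needed to tell them apart, and a single step within the scatter cannot show whether the two effects are each small or offset one another. On these data alone, how a group of another kind at this place, such as an amide or an amine, would read in this assay also stays open.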